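Replacing 5-bromopyridin-3-yl with 6-methylpyridin-3-yl

The source may hold more compounds than are shown below. What is called first, only, known or untested is meant among the compounds shown, and "the series" means these compounds.

In a functional assay on MDA-MB-231 cells (Homo sapiens) for cytotoxicity, read by MTT assay, with a stated time of 72 h (a lower number here means a stronger inhibitor, a higher number a weaker inhibitor), compound 1 (`Nc1ccccc1NC(=O)c1ccc(NC(=S)NCc2cncc(F)c2)cc1`) gives 85000 nM and compound 2 (`Nc1ccccc1NC(=O)c1ccc(NC(=S)NCc2cncc(Br)c2)cc1`) gives 39000 nM. For the measured compounds named here, compound 2 therefore holds the lower, stronger number of the two measured so far. Going by the values given here, the only measured step, a 2.2-fold lower number from compound 1 to compound 2 (0.34 log units; beyond the scatter), is modest and reflects bromo in place of fluoro on an aromatic carbon.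

Compound 3 (`Cc1ccc(CNC(=S)Nc2ccc(C(=O)Nc3ccccc3N)cc2)cn1`) has 6-methylpyridin-3-yl in place of 5-bromopyridin-3-yl on a saturated chain carbon bound to an amide-type nitrogen. Among the compounds with values here, no measured compound carries a methyl, so the measured step from bromo to fluoro offers only a rough guide to size, and a 2.2-fold lower number from compound 1 to compound 2 (0.34 log units; beyond the scatter) suggests a small effect at most. The expected change is a slight move toward a weaker number, estimated as a 1.3-fold higher number from compound 2 to compound 3 (0.11 log units; within the scatter), probably within the scatter. For compound 3 the estimated value is 50000 nM, with an expected range of 20000 nM to 120000 nM.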

Compound 3, half-maximal inhibitory concentration: 63000 nM
Compound 3: the middle estimate sits 1.3-fold (0.10 log units) below what was measured; measured number inside the range.
By their numbers in this assay, from the lowest: compounds 2, 3 and 1 (each within the scatter of the next, the first and the last beyond it).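

In this assay, 6-methylpyridin-3-yl on a saturated chain carbon bound to an amide-type nitrogen gives a 1.6-fold higher number from compound 2 to compound 3 (0.21 log units; within the scatter) and a 1.3-fold lower number from compound 1 to compound 3 (0.13 log units; within the scatter) when it takes the place of the two halogen-bearing rings. Compound 3 therefore cannot be separated from either compound 2 or compound 1, even though those two differ from each other beyond the scatter. Among these three compounds, a ring with no halogen fits within the range the halogen compounds span, and no measurement here offers an explanation for this.

Because the name changes from a 5-substituted to a 6-substituted ring, the effect of swapping the group cannot be separated from the effect of where it sits. On these data alone, it also remains open whether an amine or a carboxylic acid on this pyridine ring would move the number beyond the scatter.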